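From cyclohexyl to cyclooctyl on the amide nitrogen

The source may hold more compounds than are shown below. What is called first, only, known or untested is meant among the compounds shown, and "the series" means these compounds.

In a functional assay on MDA-MB-231 cells (Homo sapiens) for antiproliferative activity, read by WST assay, with a stated time of 72 h (on this read-out higher numbers stand for weaker inhibition and lower numbers for stronger inhibition), compound 3 `O=C(CCCCCCn1cc(C(=O)NC2CCCCC2)c2ccccc21)NO` gives > 100000 nM as a limit of the assay, not a number. Compound 1 `O=C(CCCCCCn1cc(C(=O)NCc2ccc(Cl)cc2)c2ccccc21)NO` likewise gives > 100000 nM as a limit. Of the three measured compounds, only compound 2 `O=C(CCCCCCn1cc(C(=O)Nc2ccc(Cl)cc2Cl)c2ccccc21)NO` returns a number, 16200 nM in this assay.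

Compound 4 `O=C(CCCCCCn1cc(C(=O)NC2CCCCCCC2)c2ccccc21)NO` keeps the shared core and carries cyclooctyl in place of cyclohexyl on an amide-type nitrogen. Two measured steps at this nitrogen lie beyond the scatter, an at least 6.1-fold lower number from compound 1 to compound 2 (0.79 log units; beyond the scatter) and an at least 6.1-fold higher number from compound 2 to compound 3 (0.79 log units; beyond the scatter), but both turn on the 2,4-dichlorophenyl group of compound 2. The remaining comparison, a step that the two limits leave unreadable from compound 1 to compound 3, gives no size. Going by the values given here, no measured step links one non-aromatic carbon ring to another, so no clear gain is expected, and another reading at the limit seems the likeliest result. The expected outcome is a number no higher from compound 3 to compound 4 (the limit leaves the size open), with no firm direction. For compound 4 the estimate is 100000 nM, with an expected range from 30000 nM to 300000 nM.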

Compound 4, half-maximal inhibitory concentration: > 100000 nM
Compound 4 was reported as a limit (the forecaster's own chance of this, stated with the estimate: 60%); the middle value lies on the limit itself.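

In this assay, the change from 2,4-dichlorophenyl to cyclooctyl on an amide-type nitrogen gives an at least 6.1-fold higher number from compound 2 to compound 4 (0.79 log units; beyond the scatter), so a second non-aromatic carbon ring joins cyclohexyl in giving up the readable number of compound 2. Going from the six-membered ring to the eight-membered ring brings no number into view, and the steps among compound 1, compound 3 and compound 4 cannot be read. Compound 1, compound 3 and compound 4 share one reading, a limit of the assay and not a number: the limit of > 100000 nM in this assay, at which 3 of the 4 values shown sit.

From the compounds shown here alone, it remains open whether a smaller ring such as cyclopentyl, or a cyclohexyl carrying an amine or a carboxylic acid, would return a number at this nitrogen. Also open, going by these compounds, is how much of the number of compound 2 would survive with a plain phenyl, without its two chlorine atoms.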